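Para-chloro on the benzyl of compound 1

The source may hold more compounds than are shown below. What is called first, only, known or untested is meant among the compounds shown, and "the series" means these compounds.

Going by the values given here, compound 1 `O=C(C1CCN(Cc2ccccc2)CC1)N1CCc2ccccc2C1` shows the lowest number of the three measured so far in an assay for displacement of a labelled ligand from Sigma non-opioid intracellular receptor 1 (Cavia porcellus) (a lower number here means a stronger inhibitor, a higher number a weaker inhibitor), where compound 1 gives 8.8 nM. The nearest is compound 3 `O=C(NC1CCCCC1)C1CCN(Cc2ccccc2)CC1`, which in this assay gives 15 nM, a gap that stays within the usual scatter; the furthest is compound 2 `CC(C)NC(=O)C1CCN(Cc2ccc(Cl)cc2)CC1`, which gives 637 nM, well beyond the scatter. Compound 2 and compound 1 differ in more than one place, so the two values only show that the pair sits far apart, not which part of the difference carries it.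

Compound 4 `O=C(C1CCN(Cc2ccc(Cl)cc2)CC1)N1CCc2ccccc2C1` is the next to be measured in this assay. It differs from compound 1 by chloro in place of hydrogen on an aromatic carbon. Among the compounds with values here, no measured pair in the set shows this single change on its own, so the size of the step is not known from the data. The expectation is a step without a clear direction, most likely inside the scatter, because compound 3 with the unsubstituted benzyl gives 15 nM close to compound 1. The estimated step is a 1.1-fold higher number from compound 1 to compound 4 (0.06 log units; within the scatter). For compound 4 the estimate in this assay is 10 nM, with a range from 3 nM to 40 nM.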

Compound 4, inhibition constant: 8 nM
Estimate against measurement, compound 4: 1.3-fold (0.10 log units) above, and the stated range covers the measured number.
By their numbers in this assay, from the lowest: compounds 4, 1 and 3 (each within the scatter of the next); then compound 2.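

In this assay, going by these compounds alone, the change to 4-chlorobenzyl gives a 1.1-fold lower number from compound 1 to compound 4 (0.04 log units; within the scatter) and is the first single-change step, so chloro in place of hydrogen at this carbon, para to a large group, is tolerated on the core of compound 1 with no readable shift. Compound 4 carries the same 4-chlorobenzyl as compound 2, yet compound 4 gives 8 nM and compound 2 gives 637 nM in this assay, so the chloro alone does not go with the high number of compound 2, and these two differ only in the group on the amide nitrogen. No measurement in hand offers an explanation for the size of this step.

From the compounds shown here alone, whether the same change reads alike on compound 3, with its cyclohexyl amide, remains open, since the step rests on a single pair. Also open, going by these compounds, is how this carbon responds to groups other than chloro, such as a methoxy group, a carboxylic acid or an amine.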